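The source may report more compounds than this note shows. Statements on the series, on what has been measured and on what is new or still open speak of the compounds shown alone.

Notes on the series in a functional assay on MGC-803 cells (Homo sapiens) for inhibition, read by MTT assay, with a stated time of 72 h; a higher number here means a weaker inhibitor, a lower number a stronger inhibitor. Compound 1 `C#CCSc1nc(NCCC(C)C)c2ccncc2n1` gives > 80000 nM, which is a limit of the assay. Compound 2 `C#CCSc1nc(NCCC#N)c2ccncc2n1` gives > 80000 nM, also a limit. For the measured compounds named here, compound 3 `C#CCSc1nc(Nc2ccc(C)cc2)c2ccncc2n1` gives 8090 nM, the only actual number so far. Compound 4 `C#CCSc1nc(Nc2ccc([N+](=O)[O-])cc2)c2ccncc2n1` carries nitro in place of methyl on an aromatic carbon, para to a large group (nitro in place of methyl on an aromatic carbon). The nearest measured steps, an at least 9.8-fold lower number from compound 1 to compound 3 (0.99 log units; beyond the scatter) and an at least 9.8-fold lower number from compound 2 to compound 3 (0.99 log units; beyond the scatter), replace the whole group on the nitrogen. Neither changes a group on that aromatic ring, so no step beyond the scatter is expected, and no direction is favoured. The expected step is a 1.2-fold lower number from compound 3 to compound 4 (0.06 log units; within the scatter). Taking compound 3 at 8090 nM as the anchor, compound 4 is estimated at 7000 nM, with an expected range of 2500 nM to 25000 nM.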

Compound 4, half-maximal inhibitory concentration: > 80000 nM
Compound 4 was reported as a limit (the forecaster's own chance of this, stated with the estimate: 8%); middle value at least 11-fold (1.05 log units) away from the limit.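

In this assay, nitro in place of methyl on the aromatic carbon para to a large group gives a clear loss (an at least 9.8-fold higher number from compound 3 to compound 4 (0.99 log units; beyond the scatter)) and shows that a change on this ring alone, with the nitrogen substituent still an aromatic ring, can move the read-out. As far as these compounds go, compound 4 is reported only as a limit, so the size of this step stays open-ended: (the limit of > 80000 nM in this assay, at which 3 of the 4 values shown sit). The step between compound 1 and compound 2 cannot be read.

From the compounds shown here alone, whether an amine, a methoxy group or a chlorine at this carbon would stay near compound 3 remains open. With one measured number in the series, no trend across groups on this ring can be drawn.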